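The source may hold more compounds than are shown below. What is called first, only, known or untested is meant among the compounds shown, and "the series" means these compounds.

Compound 1 `O=C(NNc1ccc(F)cc1)c1ccc(NS(=O)(=O)c2cnc(O)nc2O)cc1`: in a functional assay on SGC-7901 cells (Homo sapiens) for antiproliferative activity, read by MTT assay, with a stated time of 24 h (a lower number here means a stronger inhibitor, a higher number a weaker inhibitor), compound 1 gives > 20000 nM, which is a limit of the assay rather than a number.
Compound 2 `O=C(NNc1ccccc1Cl)c1ccccc1NS(=O)(=O)c1cnc(O)nc1O`: in this assay compound 2 gives > 20000 nM, likewise a limit.

Within the data shown here, compound 2 therefore stands at the limit, where both known values sit (the limit of > 20000 nM in this assay, at which 2 of the 2 values shown sit), so no measured step is available. Compound 3 `O=C(NNC(=O)c1ccccc1NS(=O)(=O)c1cnc(O)nc1O)c1ccc(F)cc1` carries (4-fluorophenyl)carbonyl in place of 2-chlorophenyl on an amine nitrogen. Since compound 2 shows only a limit, the step expected from compound 2 to compound 3 is a step that the limit leaves unreadable from compound 2 to compound 3, and no direction beyond the scatter can be claimed. Compound 3 is expected to give 25000 nM, in the range 8000 nM to 80000 nM, quite possibly again reported only as a limit.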

Compound 3, half-maximal inhibitory concentration: > 20000 nM
Compound 3 gave a limit, no number; the forecaster's own chance of this, stated with the estimate: 65%; the middle value does not contradict the limit.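

No step can be read from compound 2 to compound 3, since both values are limits: the limit of > 20000 nM in this assay, at which 3 of the 3 values shown sit.

The compounds shown leave open what (4-fluorophenyl)carbonyl in place of 2-chlorophenyl does in this assay, and how strongly any of them acts there.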